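Swapping ethyl for cyclobutyl: what happens to solubility?

The source may hold more compounds than are shown below. What is called first, only, known or untested is meant among the compounds shown, and "the series" means these compounds.

compound 1 (`CCn1c(NC(C)C)nc2c(C3CCNCC3)csc2c1=O`) gives 1100 ug/mL
compound 2 (`CCNc1nc2ccsc2c(=O)n1CC`) gives 240 ug/mL
compound 3 (`CCn1c(N[C@H]2CC[C@H](O)CC2)nc2ccsc2c1=O`) gives 74 ug/mL

All three values come from a physicochemical assay for solubility, in phosphate buffer, at pH 6.8 (a lower number here means a less soluble compound, a higher number a more soluble compound), and compound 2 stands second of the three. It lies under compound 1 and over compound 3, and both gaps are beyond the scatter.

The next compound is compound 4 (`CCn1c(NC2CCC2)nc2ccsc2c1=O`), with cyclobutyl in place of ethyl on a nitrogen on an aromatic ring. Among the compounds with values here, no two measured compounds differ in one place only, so nothing yet shows this change alone. Compound 3 (74 ug/mL) also carries a ring on that nitrogen and offers the closest, though weak, guide. Compound 1 (1100 ug/mL) differs from compound 2 in more than one place and offers little guidance.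

In this assay a modest fall is expected, probably just beyond the scatter, with the estimated change being a 2.4-fold lower number from compound 2 to compound 4 (0.38 log units; beyond the scatter) at its middle. The estimated value for compound 4 is 100 ug/mL (expected range 35 ug/mL to 260 ug/mL).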

Compound 4, solubility: 6.3 ug/mL
The estimate for compound 4 lay 16-fold (1.20 log units) above the measured number; the whole stated range lies above it.
By their numbers in this assay, from the lowest: compound 4; then compound 3; then compound 2; then compound 1.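

In this assay, within the data shown here, this nitrogen proves sensitive to a small swap: putting cyclobutyl in place of ethyl gives a 38-fold lower number from compound 2 to compound 4 (1.58 log units; beyond the scatter) and provides the first reading of a single change in this set. Having a ring on that nitrogen does not alone fix the value, since compound 3, which also has a ring there, gives 74 ug/mL while compound 4 gives 6.3 ug/mL and the two rings differ. No measurement shown here explains the fall.

Still open, on these data alone, is whether the closed ring or simply the larger number of carbons goes with the low value, which an open-chain butyl group on the same nitrogen could help separate. Cyclopropyl and cyclopentyl would show whether ring size matters at this position.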